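A Fourth Analogue Awaits Its Measurement

A few compounds are considered here, and "the series" means these few. Any claim that something is new, unique, unknown or untested is made for them only; others in the source may bear on it.

Compound 3 `CC(C)(C)Cc1c(-c2ccccn2)sc(N)c1C(=O)c1ccc(Cl)cc1` is the reference point of this account. In an assay on CHO cells for displacement of a labelled ligand from adenosine receptor A1 (Homo sapiens), read by scintillation counting, tested at 10 uM (on this read-out higher numbers stand for more inhibition at the one concentration tested (going by the name of the read-out) and lower numbers for less inhibition), compound 3 gives 1%. Its two companions sit at the same level: compound 1 `CC(C)Cc1csc(N)c1C(=O)c1ccc(Cl)cc1` gives 1% in this assay, and compound 2 `Cc1c(Br)sc(N)c1C(=O)c1ccc(Cl)cc1` gives 1% in this assay. Compound 3 therefore stands level with compound 1 and compound 2 at the digits shown, with no change within the scatter toward either of them, so none of the three can be called stronger or weaker than another.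

Compound 4 `COc1ccccc1-c1sc(N)c(C(=O)c2ccc(Cl)cc2)c1CC(C)(C)C` has not yet been measured in this assay. It differs from compound 3 in one place: 2-methoxyphenyl in place of pyridin-2-yl on an aromatic carbon. Within the data shown here, no step between two measured compounds is known here, and all three measured values lie at the floor of the read-out, so the change is expected to stay within the scatter, without a direction to call: a number 1 percentage points higher from compound 3 to compound 4 (within the scatter). Compound 4 is accordingly estimated to give 2% in this assay, with a range from -8% to 12%.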

Compound 4, a percentage reported as inhibition, at one concentration (the size of the read-out at that concentration, not a potency): 1%
Estimate against measurement, compound 4: 1 percentage points above, within the range that was stated.
By their numbers in this assay, from the lowest: compounds 1, 2, 3 and 4 (each within the scatter of the next).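

In this assay, among these compounds, the first step between two measured compounds reads no change at the digits printed from compound 3 to compound 4 (within the scatter) and so gives this position its first direct comparison. On the aromatic carbon next to the ring sulfur and next to the ring atom that bears a neopentyl group, 2-methoxyphenyl with its ring of carbon only and 8 heavy atoms reads the same as pyridin-2-yl with its ring nitrogen and 6 heavy atoms, so this exchange alone does not lift the read-out from the floor shared by all four compounds. Nothing measured here bears on why the two groups read alike.

A step at the floor of the read-out leaves open whether these two groups would also read alike on a compound with a clearly higher value. Also open, going by these compounds, is what an amine, a carboxylic acid or a longer chain on this same aromatic carbon would give in this assay and whether any such group would move the read-out away from the level of these four compounds.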